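The compounds below may be only part of what the source reports. "The series", "measured", "known", "first", "only" and "open" are said of these compounds alone.

Measured so far:
compound 1 `c1ccc2c(c1)CCC2NC1CCN(CCCc2c[nH]c3ccc(-n4cnnc4)cc23)CC1` — in a functional assay on CHO cells for activation of 5-hydroxytryptamine receptor 1D (Homo sapiens), read by GTPgammaS binding (a lower number here means a smaller maximal response, a higher number a larger maximal response), compound 1 gives 68%
compound 2 `CC(=O)Nc1ccc(CNC2CCN(CCCc3c[nH]c4ccc(-n5cnnc5)cc34)CC2)cc1` — in this assay compound 2 gives 75%

Compound 2 holds the higher of the two numbers seen so far, but the step of a number 7 percentage points higher from compound 1 to compound 2 (within the scatter) stays within the scatter, so the two compounds read as equivalent on the maximal response. Compound 3 `OCCC(NC1CCN(CCCc2c[nH]c3ccc(-n4cnnc4)cc23)CC1)c1ccccc1` differs from compound 2 by 3-hydroxy-1-phenylpropyl in place of 4-acetamidobenzyl on an amine nitrogen. Among the compounds with values here, the only measured step that bears on this place is the exchange of the whole substituent on the same amine nitrogen, a number 7 percentage points higher from compound 1 to compound 2 (within the scatter), and it did not move the read-out beyond the scatter. On that basis no step beyond the scatter is expected here either, and the estimated change from the measured value of compound 2 is a number 4 percentage points lower from compound 2 to compound 3 (within the scatter). For compound 3 the expected value in this assay is therefore 71%, with a range from 55% to 87%.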

Compound 3, largest response reached (reported as efficacy), in percent of the reference or control that the assay uses: 100%
Estimate against measurement, compound 3: 29 percentage points below; the whole stated range lies below it.
By their numbers in this assay, from the lowest: compounds 1 and 2 (each within the scatter of the next); then compound 3.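

Within the data shown here, on the amine nitrogen, 3-hydroxy-1-phenylpropyl gives the first change beyond the scatter in this assay, with a number 25 percentage points higher from compound 2 to compound 3 (beyond the scatter) against 4-acetamidobenzyl and a number 32 percentage points higher from compound 1 to compound 3 (beyond the scatter) against 2,3-dihydro-1H-inden-1-yl. The maximal response therefore does depend on the substituent at this place, which the step within the scatter between the two earlier compounds did not reveal, and compound 3 stands clear of both. No supporting measurement bears on why this substituent differs from the other two.

The compounds shown do not separate the contribution of the hydroxyl from that of the rest of the 3-hydroxy-1-phenylpropyl group. A plain 1-phenylpropyl group, or an amine or a carboxylic acid in place of the hydroxyl, would address that question.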